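The source may hold more compounds than are shown below. What is called first, only, known or untested is meant among the compounds shown, and "the series" means these compounds.

Of the compounds shown here, three sharing one core have been measured so far in a functional assay on SK-HEP1 cells (Homo sapiens) for cytotoxicity, read by MTT assay, with a stated time of 48 h (a higher number here means a weaker inhibitor, a lower number a stronger inhibitor), for cytotoxicity. Compound 1 (`C#Cc1cccc(Nc2nc(Cl)nc3cc(OC)c(OC)cc23)c1`) gives 7500 nM there, and compound 2 (`COc1cc2nc(Cl)nc(Nc3cccc(Cl)c3)c2cc1OC`) gives 16500 nM there. Compound 3 (`COc1cc2nc(Cl)nc(Nc3cc(C)ccc3F)c2cc1OC`) stands at > 40000 nM in this assay and this is a limit, not a number. Compound 4 (`COc1cc2nc(Cl)nc(NCc3ccccc3)c2cc1OC`) differs from compound 3 in one place (benzyl in place of 2-fluoro-5-methylphenyl on a nitrogen on an aromatic ring) with benzyl in place of 2-fluoro-5-methylphenyl on a nitrogen on an aromatic ring. The measured steps that change the group at this place are an at least 5.3-fold higher number from compound 1 to compound 3 (0.72 log units; beyond the scatter) and an at least 2.4-fold higher number from compound 2 to compound 3 (0.38 log units; beyond the scatter) and both lie beyond the scatter, though neither brings in benzyl. With those two steps as the guide, the change expected in this assay is modest and toward a lower number (an at least 1.6-fold lower number from compound 3 to compound 4 (0.20 log units; that floor lies within the scatter)) although another limit remains possible. Compound 4 is estimated at 25000 nM with an expected range from 10000 nM to 50000 nM in this assay once it is measured.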

Compound 4, half-maximal inhibitory concentration: 19800 nM
For compound 4 the middle estimate is 1.3-fold (0.10 log units) above the measured one; the measured number falls inside the stated range.
By their numbers in this assay, from the lowest: compound 1; then compounds 2 and 4 (each within the scatter of the next). At a limit, above all of these: compound 3.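

Benzyl is the first group at this place that is not a substituted phenyl, and in this assay it cannot be told apart from 3-chlorophenyl, with a 1.2-fold higher number from compound 2 to compound 4 (0.08 log units; within the scatter), while 3-ethynylphenyl stays ahead of it, with a 2.6-fold higher number from compound 1 to compound 4 (0.42 log units; beyond the scatter). Against 2-fluoro-5-methylphenyl the change reads only as an at least 2.0-fold lower number from compound 3 to compound 4 (0.30 log units; that floor lies within the scatter), which is a floor and not a size. That floor rests on compound 3, whose value is a limit and not a number: the limit of > 40000 nM in this assay, at which 1 of the 4 values shown sits.

The compounds shown leave open whether the ring matters at this place at all, as no open-chain group such as butyl stands on this nitrogen. They also leave open how phenethyl, or a benzyl carrying an amine or a carboxylic acid, would read in this assay.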